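Series notes: compound 1 to compound 4

The source may hold more compounds than are shown below. What is called first, only, known or untested is meant among the compounds shown, and "the series" means these compounds.

Measured in a physicochemical assay for lipophilicity, read by HPLC, measured as octanol-water partition; a higher number here means a more lipophilic compound, a lower number a more polar compound:
- compound 1 `Nc1ccccc1C(=O)N/N=C/c1ccc2no[n+]([O-])c2c1`: 2
- compound 2 `N#Cc1c(-c2ccccc2)[n+]([O-])c2ccc(/C=N/NC(=O)c3ccncc3)cc2[n+]1[O-]`: 1
- compound 3 `NC(=O)c1c(COc2ccccc2/C=N/NC(=O)c2ccncc2)no[n+]1[O-]`: 1.3

Compound 1 stands highest of the three in this assay, and both compound 2 and compound 3 lie below it by more than the scatter. Going by the values given here, these gaps are a poor guide to any single change, since no two measured compounds differ in one place only. Among the compounds with values here, the series therefore offers no measured step for the change now in view.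

The next compound is compound 4 `O=C(N/N=C/c1ccc2no[n+]([O-])c2c1)c1cccc(O)c1`, not yet measured. It keeps the core of compound 1 and changes one group: 3-hydroxyphenyl in place of 2-aminophenyl on a carbonyl carbon. In words, 3-hydroxyphenyl stands in place of 2-aminophenyl on a carbonyl carbon. The two groups count alike, except that oxygen takes the place of nitrogen.

With so even an exchange, and with compound 1 at 2 as the only anchor, a small downward move in this assay is expected, not beyond the scatter. The expected size is a number 0.20 log units lower from compound 1 to compound 4 (within the scatter). Compound 4 is estimated at 1.8, with an expected range of 1.3 to 2.3.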

Compound 4, partition coefficient: 1.2
The estimate for compound 4 lay 0.60 log units above the measured number; the measured number lies below the stated range.
By their numbers in this assay, from the lowest: compounds 2, 4 and 3 (each within the scatter of the next); then compound 1.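

In this assay, going by these compounds alone, 3-hydroxyphenyl in place of 2-aminophenyl on a carbonyl carbon gives a number 0.80 log units lower from compound 1 to compound 4 (beyond the scatter), the first step that can be read at a single place. Matching counts for the two groups therefore do not make the exchange neutral at this position: the leaving and entering groups have the same number of heavy atoms, hydrogen-bond donors and hydrogen-bond acceptors, yet the step lies beyond the scatter. Nothing measured for these compounds accounts for the size or direction of the step.

Within the data shown here, the single step leaves open how much belongs to losing 2-aminophenyl and how much to gaining 3-hydroxyphenyl, and a plain phenyl on the same carbonyl carbon would give each group its own step from the shared core. From the compounds shown here alone, whether a similar step would appear on another core also stays open, since compound 2 and compound 3 each differ from compound 1 and compound 4 in more than one place.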